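Adding One More Carbon to the Chain

The source may hold more compounds than are shown below. What is called first, only, known or untested is meant among the compounds shown, and "the series" means these compounds.

Among the compounds with values here, in a physicochemical assay for lipophilicity, read by HPLC, measured as octanol-water partition (a lower number here means a more polar compound, a higher number a more lipophilic compound), compound 1 `Cc1nc(O)c2c[nH]nc2n1` gives -0.05, while compound 2 `CCc1nc(O)c2c[nH]nc2n1` gives 0.52, the highest of the two numbers measured so far. These two compounds share a core and differ only in the chain attached to it.

Compound 3 `CCCc1nc(O)c2c[nH]nc2n1` extends that chain, going from ethyl to propyl: methyl in place of hydrogen on a saturated chain carbon, two bonds along the chain from an aromatic carbon. Put in words, this is a methyl in place of hydrogen on a saturated chain carbon, two bonds along the chain from an aromatic carbon.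

Within the data shown here, only one measured step bears on this change. It is a number 0.57 log units higher from compound 1 to compound 2 (beyond the scatter), which came from a methyl in place of hydrogen on a saturated chain carbon bound to an aromatic carbon. The added group is the same, but the place differs, and a single step cannot show whether a further addition will repeat the first. Among the measured compounds shown here, with only that step as a guide, the estimated change is a number 0.48 log units higher from compound 2 to compound 3 (beyond the scatter), in the same upward direction and of similar size. In this assay the estimate for compound 3 is 1, expected to fall between 0.7 and 1.3.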

Compound 3, partition coefficient: 1.14
Compound 3: the middle estimate sits 0.14 log units below what was measured; the measured number falls inside the stated range.
By their numbers in this assay, from the lowest: compound 1; then compound 2; then compound 3.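

In this assay this chain now has a second step, a number 0.62 log units higher from compound 2 to compound 3 (beyond the scatter) in the same direction as a number 0.57 log units higher from compound 1 to compound 2 (beyond the scatter) and likewise modest, so a methyl in place of hydrogen raises the number on a saturated chain carbon, two bonds along the chain from an aromatic carbon, as well as on the carbon bound to the aromatic ring. Taken as one change, the two steps add up to a number 1.19 log units higher from compound 1 to compound 3 (beyond the scatter) and this is large, so across these three compounds, with none going against it, the number rises with each carbon added to the chain on the shared core. No supporting measurement here explains why the number rises.

Three compounds cannot show how far this rise continues, and a longer chain such as butyl or hexyl could extend it or depart from it. A branched chain such as isopropyl, or an amine or a carboxylic acid at the end of the propyl chain, could also give a quite different number, and these compounds offer no guide to either.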